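A few compounds are considered here, and "the series" means these few. Any claim that something is new, unique, unknown or untested is made for them only; others in the source may bear on it.

In a functional assay on Hs 683 cells (Homo sapiens) for inhibition, read by MTT assay, with a stated time of 72 h (on this read-out higher numbers stand for weaker inhibition and lower numbers for stronger inhibition), compound 2 `CCc1oc([C@H](C)/C=C(\C)[C@H](OC(C)=O)[C@H](C)[C@@H](OC(=O)CC(C)C)[C@@H](C)c2oc([C@@H](C)[C@H](CC)OC(C)=O)c(C)c(=O)c2C)c(C)c(=O)c1C` gives 24000 nM, a number within the scatter of compound 1 `CCC(=O)O[C@@H](/C(C)=C/[C@@H](C)c1oc(CC)c(C)c(=O)c1C)[C@H](C)[C@@H](OC(=O)CC(C)C)[C@@H](C)c1oc([C@@H](C)[C@@H](O)CC)c(C)c(=O)c1C` at 13000 nM. Compound 3 `CCc1oc([C@H](C)/C=C(\C)[C@H](O)[C@H](C)[C@@H](OC(=O)CC(C)C)[C@@H](C)c2oc([C@@H](C)[C@@H](O)CC)c(C)c(=O)c2C)c(C)c(=O)c1C` gives only a limit of the assay, > 100000 nM.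

Compound 4 `CCC(=O)O[C@@H](/C(C)=C/[C@@H](C)c1oc(CC)c(C)c(=O)c1C)[C@H](C)[C@@H](OC(=O)CC(C)C)[C@@H](C)c1oc([C@@H](C)[C@H](CC)OC(C)=O)c(C)c(=O)c1C`, not yet measured, departs from compound 2 by methyl in place of hydrogen on a saturated chain carbon bound to a carbonyl carbon, which also reads as acetyl to propanoyl. For the measured compounds named here, no measured step shows this change itself. The nearest one is an at least 7.6-fold higher number from compound 1 to compound 3 (0.88 log units; beyond the scatter), with hydrogen in place of propanoyl on an oxygen on a saturated carbon. That step lies beyond the scatter, but it takes the whole propanoyl away, and its far end is a limit rather than a number. In compound 4 the acyl group stays and only gains a methyl, so the size of that step is not expected to carry over. No step beyond the scatter is therefore expected in this assay, in either direction. The estimated step is a 1.2-fold lower number from compound 2 to compound 4 (0.08 log units; within the scatter). For compound 4 the expected value is 20000 nM, with an estimated range from 8000 nM to 50000 nM.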

Compound 4, half-maximal inhibitory concentration: 3000 nM
Compound 4: the middle estimate sits 6.7-fold (0.82 log units) above what was measured; measured number outside the range, below it.
By their numbers in this assay, from the lowest: compound 4; then compounds 1 and 2 (each within the scatter of the next). At a limit, above all of these: compound 3.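

In this assay, turning acetyl into propanoyl on this oxygen gives an 8.0-fold lower number from compound 2 to compound 4 (0.90 log units; beyond the scatter), so a single added methyl on a saturated chain carbon bound to a carbonyl carbon is enough to move the number beyond the scatter. The earlier step, an at least 7.6-fold higher number from compound 1 to compound 3 (0.88 log units; beyond the scatter), could not show this, since it takes the whole propanoyl away and ends at a limit, whereas here the acyl group stays and only its chain changes. The second acylated oxygen also counts once the propanoyl is in place, as acetyl in place of hydrogen there gives a 4.3-fold lower number from compound 1 to compound 4 (0.64 log units; beyond the scatter).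

For the compounds shown here, whether the trend goes on with a longer chain such as butanoyl, or holds with a benzoyl group, remains open, and so does whether the same methyl added to the other acetyl, the one compound 4 keeps, would give a step of similar size. All of this rests on a single cell-based read-out, so how far the step carries to other cells is also left open.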